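Cyclobutyl for methyl on the ring nitrogen of compound 1

The compounds below may be only part of what the source reports. "The series", "measured", "known", "first", "only" and "open" are said of these compounds alone.

Three compounds share a core in an assay on V79 cells for inhibition of cytochrome P450 11B1, mitochondrial (Homo sapiens), read by HTRF, with a stated time of 1 h; a higher number here means a weaker inhibitor, a lower number a stronger inhibitor. Compound 1 `Cn1c(-c2cccnc2)nc2ccc(F)cc21` gives 677 nM, the highest of the two numbers recorded. Compound 2 `Fc1cncc(-c2nc3cc(F)c(Cl)cc3n2C2CC2)c1` gives 251 nM, a lower number by a margin beyond the scatter. Compound 3 `Fc1cccc2c1nc(-c1cccnc1)n2C1CC1` returned only a limit, > 8330 nM, so no number is known for it; the limit of > 8330 nM in this assay, at which 1 of the 3 values shown sits, marks that limit. No pair among these differs in one place, so no single step is measured. Compound 4 `Fc1ccc2nc(-c3cccnc3)n(C3CCC3)c2c1` introduces one change relative to compound 1: cyclobutyl in place of methyl on an aromatic nitrogen. For the measured compounds named here, with no measured step to guide the direction, the expected change is small, and compound 4 is estimated at 450 nM, between 130 nM and 1500 nM, a step of a 1.5-fold lower number from compound 1 to compound 4 (0.18 log units; within the scatter) that may not exceed the scatter.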

Compound 4, half-maximal inhibitory concentration: > 10000 nM
Compound 4: a limit, no number (the forecaster's own chance of this, stated with the estimate: 10%); middle value at least 22-fold (1.34 log units) away from the limit.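

Cyclobutyl in place of methyl on an aromatic nitrogen gives an at least 14-fold higher number from compound 1 to compound 4 (1.16 log units; beyond the scatter) in this assay, the only measured step at this position, and it runs towards a weaker inhibitor. The size of this step is only a lower bound, as compound 4 gives a limit of the assay and not a number: the limit of > 10000 nM in this assay, at which 1 of the 4 values shown sits.

The compounds shown leave open how ethyl, isopropyl or a longer chain on this nitrogen would read. They also leave open whether the ring of cyclobutyl or its carbon count accounts for the step.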